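Dropping the Ring Benzyl: Will Cytotoxicity Change?

A few compounds are considered here, and "the series" means these few. Any claim that something is new, unique, unknown or untested is made for them only; others in the source may bear on it.

Compound 1, `COC(=O)C[C@H](NC(=O)OC(C)(C)C)C(=O)N(Cc1ccccc1)C1(C(=O)NCc2ccccc2)CCN(Cc2ccccc2)CC1`, in an ADME assay on MDCK cells (Canis lupus familiaris) for cytotoxicity, read by microscopy, with a stated time of 72 h (a higher number here means that more compound is tolerated, a lower number that less compound is tolerated), is reported only as a limit: > 100000 nM.
Compound 2, `COC(=O)C[C@H](NC(=O)OC(C)(C)C)C(=O)N(Cc1ccc(F)cc1)C1(C(=O)NCc2ccccc2)CCN(Cc2ccccc2)CC1`, in this assay likewise sits at a limit: > 100000 nM.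
Compound 3, `COC(=O)C[C@H](NC(=O)OC(C)(C)C)C(=O)N(Cc1ccc(F)cc1)C(C)(C)C(=O)NCc1ccccc1`, in this assay gives 20000 nM.

Going by these compounds, compound 2 therefore stands at the limit of > 100000 nM in this assay, at which 2 of the 3 values shown sit, so its true value is unknown beyond that edge. The step that the two limits leave unreadable from compound 1 to compound 2 is unreadable for the same reason. Compound 4, `COC(=O)C[C@H](NC(=O)OC(C)(C)C)C(=O)N(Cc1ccc(F)cc1)C1(C(=O)NCc2ccccc2)CCNCC1`, differs from compound 2 as follows: hydrogen in place of benzyl on an amine nitrogen in a ring. Among the measured compounds shown here, no measured step involves this amine nitrogen, so nothing among the known steps speaks for or against a change in this assay, and no step beyond the scatter is expected. Compound 4 is estimated at 100000 nM, spanning 25000 nM to 200000 nM, an expected step of a number no higher from compound 2 to compound 4 (the limit leaves the size open).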

Compound 4, minimum cytotoxic concentration: 100000 nM
Estimate against measurement, compound 4: no gap at the digits printed, within the range that was stated.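

Among the compounds shown here, this is the first measured change at the amine nitrogen in the ring. In this assay compound 4, which carries hydrogen there, gives a true number, 100000 nM, and the change is a number no higher from compound 2 to compound 4 (the limit leaves the size open). Its size cannot be read, as compound 2 is reported only as a limit: the limit of > 100000 nM in this assay, at which 2 of the 4 values shown sit.

Still open, going by these compounds, is how a methyl or an acetyl group on this nitrogen would read in this assay. Also open, on these data alone, is what a carboxylic acid in place of the methyl ester would do.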